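Plasma half-life notes: aryl ester variation on compound 1

The source may hold more compounds than are shown below. What is called first, only, known or untested is meant among the compounds shown, and "the series" means these compounds.

Measured so far:
compound 1 `CC(=O)Oc1ccccc1C(=O)O[C@H]1CO[C@H]2[C@@H]1OC[C@H]2OC(=O)c1cccc(O)c1`: 0.015 h
compound 2 `CC(=O)Oc1ccccc1C(=O)O[C@H]1CO[C@H]2[C@@H]1OC[C@H]2OC(=O)c1ccc(C)cc1`: 0.0362 h

In an ADME assay on a cell-free system (plasma, Homo sapiens) for metabolic stability, with Plasma (Rattus norvegicus) as the target, read by HPLC, at pH 7.4 (a lower number here means that the compound disappears faster, a higher number that the compound lasts longer), compound 1 gives 0.015 h, the lowest of the two numbers; compound 2 gives 0.0362 h, a longer half-life by a 2.4-fold higher number from compound 1 to compound 2 (0.38 log units; beyond the scatter). Compound 3 `CC(=O)Oc1ccccc1C(=O)O[C@H]1CO[C@H]2[C@@H]1OC[C@H]2OC(=O)c1ccncc1` differs from compound 1 by pyridin-4-yl in place of 3-hydroxyphenyl on a carbonyl carbon. Going by the values given here, the one measured step that bears on this change is a 2.4-fold higher number from compound 1 to compound 2 (0.38 log units; beyond the scatter), which removes the same 3-hydroxyphenyl group but brings in 4-methylphenyl rather than pyridin-4-yl, so it gives only a sense of scale, not of direction. On that basis a step of similar or smaller size is expected, and it may well stay within the scatter. The step expected from compound 1 to compound 3 is a 1.3-fold higher number from compound 1 to compound 3 (0.12 log units; within the scatter). For compound 3 the expected half-life in this assay is 0.02 h, with a range of 0.008 h to 0.05 h.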

Compound 3, half-life: 0.0055 h
For compound 3 the middle estimate is 3.6-fold (0.56 log units) above the measured one, outside the stated range (below it).
By their numbers in this assay, from the lowest: compound 3; then compound 1; then compound 2.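

With this assay as the read-out, the aryl group on this carbonyl carbon can shift the half-life in either direction, not only upward as the first step showed: pyridin-4-yl in place of 3-hydroxyphenyl gives a 2.7-fold lower number from compound 1 to compound 3 (0.44 log units; beyond the scatter). Pyridin-4-yl in place of 4-methylphenyl gives a 6.6-fold lower number from compound 2 to compound 3 (0.82 log units; beyond the scatter), the largest step among the three compounds, so the choice of aryl group here matters beyond the scatter. Nothing available explains why the pyridin-4-yl ester lasts for the shortest time.

The compounds shown leave open whether pyridin-3-yl, 4-aminophenyl or a saturated cyclohexyl group on this carbonyl carbon would fall inside or outside this span. They also do not show which of the ester groups in these compounds is lost first.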